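Hydroxyethyl amide in place of cyanoethyl amide

A few compounds are considered here, and "the series" means these few. Any claim that something is new, unique, unknown or untested is made for them only; others in the source may bear on it.

Compound 3 `Cc1ccc(Sc2cnc(Nc3ccccn3)s2)cc1C(=O)NCCC#N` gives 65 nM in an assay on isolated protein for inhibition of high affinity nerve growth factor receptor (Homo sapiens) (a higher number here means a weaker inhibitor, a lower number a stronger inhibitor), and stands lowest of the two numbers seen; the nearest is compound 1 `Cc1ccc(Sc2cnc(Nc3ccccn3)s2)cc1C(N)=O` with 790 nM, the step being a 12-fold lower number from compound 1 to compound 3 (1.08 log units; beyond the scatter). Compound 2 `CCNC(=O)c1cc(Sc2cnc(Nc3ccccn3)s2)ccc1C` reaches only a limit of the assay, > 5000 nM. This is the limit of > 5000 nM in this assay, at which 1 of the 3 values shown sits. From this limit the step of an at least 6.3-fold higher number from compound 1 to compound 2 (0.80 log units; beyond the scatter) and the step of an at least 76-fold lower number from compound 2 to compound 3 (1.88 log units; beyond the scatter) are read, the latter being the one that bears on the present question, since it shows what the cyano group at this position brought.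

Compound 4 `Cc1ccc(Sc2cnc(Nc3ccccn3)s2)cc1C(=O)NCCO` differs from compound 3 by hydroxy in place of cyano on a saturated chain carbon, two bonds along the chain from an amide-type nitrogen. For the measured compounds named here, the cyano group whose entry gave the large step from compound 2 to compound 3 is removed, so a move back toward a higher number is expected in this assay; the incoming hydroxy group has no counterpart among the measured compounds, so the size is uncertain. The step expected is a 3.8-fold higher number from compound 3 to compound 4 (0.59 log units; beyond the scatter), modest. For compound 4 the estimate is 250 nM, with a range from 70 nM to 900 nM.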

Compound 4, half-maximal inhibitory concentration: 760 nM
Beside the measured number, compound 4's estimate is 3.0-fold (0.48 log units) below it; low and high end bracket the measured number.
By their numbers in this assay, from the lowest: compound 3; then compounds 4 and 1 (each within the scatter of the next). At a limit, above all of these: compound 2.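

Replacing the chain end shows that the low number of compound 3 is tied to cyano at this place and is not shared by hydroxy, with a 12-fold higher number from compound 3 to compound 4 (1.07 log units; beyond the scatter) in this assay and with a 1.0-fold lower number from compound 1 to compound 4 (0.02 log units; within the scatter) so that the 2-hydroxyethyl amide and the unsubstituted amide cannot be told apart. Hydroxy on the chain still separates the 2-hydroxyethyl amide from the ethyl amide, with an at least 6.5-fold lower number from compound 2 to compound 4 (0.81 log units; beyond the scatter) as a bound and not an exact size. Compound 2 stands at a limit and has no exact number: the limit of > 5000 nM in this assay, at which 1 of the 4 values shown sits.

Open, from the compounds shown here alone, is whether a 2-aminoethyl amide, a 2-methoxyethyl amide or a 3-cyanopropyl amide would sit with compound 3 or with compound 4. The compounds shown also do not tell why cyano and hydroxy differ at this place.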